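The source may report more compounds than this note shows. Statements on the series, on what has been measured and on what is new or still open speak of the compounds shown alone.

In a functional assay on MCF7 cells (Homo sapiens) for antiproliferative activity, read by MTT assay, with a stated time of 72 h (on this read-out higher numbers stand for weaker inhibition and lower numbers for stronger inhibition), the measured compounds stand as follows.
Compound 1, `COc1ccc(/C=C2\S/C(=N\c3ccc(F)cc3)N(C)C2=O)cc1`, gives 66500 nM.
Compound 2, `COc1ccc(/C=C2\S/C(=N\c3ccc(OC)cc3)N(C)C2=O)cc1`, gives only the limit > 100000 nM.
Compound 3, `C=CC/N=C1\S/C(=C\c2ccc(OC)cc2)C(=O)N1C`, gives only the limit > 100000 nM.

Compound 3 therefore sits at the assay's limit, where (the limit of > 100000 nM in this assay, at which 2 of the 3 values shown sit), so no number is known for it and its true activity is weaker than any point that could be read. Compound 4, `COc1ccc(/C=C2\S/C(=N\c3ccc(Br)cc3)N(C)C2=O)cc1`, differs from compound 3 in a single place: 4-bromophenyl in place of allyl on a double-bonded nitrogen. The step that bears most closely on this change is the reverse of an at least 1.5-fold higher number from compound 1 to compound 3 (0.17 log units; that floor lies within the scatter), which put an allyl group where a halogen-bearing aromatic ring had been and moved the number from a measured value to the limit. Going back from allyl to an aromatic ring carrying a halogen may therefore bring compound 4 down from the limit toward the number seen for compound 1, though the halogen itself differs. The step that the two limits leave unreadable from compound 2 to compound 3 gives no readable size, so it adds nothing here. The expected step in this assay is thus a lower number, an at least 1.6-fold lower number from compound 3 to compound 4 (0.22 log units; that floor lies within the scatter), with a size that cannot be fixed closely. Compound 4 is estimated at 60000 nM, within 20000 nM to 150000 nM.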

Compound 4, half-maximal inhibitory concentration: > 100000 nM
Compound 4: no number, only a limit (the forecaster's own chance of this, stated with the estimate: 40%); middle value at least 1.6-fold (0.22 log units) away from the limit.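

In this assay compound 4 gives > 100000 nM, which is a limit and not a number. An aromatic ring carrying a halogen on the double-bonded nitrogen is therefore not enough on its own to give a readable value, and compound 1, with fluoro where compound 4 has bromo, is the only one of the four with a number, the others sharing a single limit: the limit of > 100000 nM in this assay, at which 3 of the 4 values shown sit. Changing fluoro to bromo gives an at least 1.5-fold higher number from compound 1 to compound 4 (0.17 log units; that floor lies within the scatter), so this floor does not show that bromo truly does worse than fluoro, and the steps to compound 4 from compound 2 and compound 3 cannot be read, as both ends of each are limits.

On these data alone, the true values of compound 2, compound 3 and compound 4 remain unknown, so it stays open whether fluoro really sets compound 1 apart or whether all four lie close together near the top of the range. Also open, as far as these compounds go, is whether chloro, an amine or a carboxylic acid in that place on the aromatic ring would give a readable number.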